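A few compounds are considered here, and "the series" means these few. Any claim that something is new, unique, unknown or untested is made for them only; others in the source may bear on it.

Working notes on the series in a functional assay on PC-3 cells (Homo sapiens) for inhibition, read by MTT assay, with a stated time of 48 h; a higher number here means a weaker inhibitor, a lower number a stronger inhibitor. Compound 1 `COc1cc(-c2nnc(SCc3ccccc3)n2-c2ccc(N(C)C)cc2)cc(OC)c1OC` gives 55800 nM. Compound 2 `COc1ccc(CSc2nnc(-c3cc(OC)c(OC)c(OC)c3)n2-c2ccc(N(C)C)cc2)cc1` reads > 60000 nM, which is a limit of the assay and not a number. Compound 3 `COc1ccc(C(=O)CSc2nnc(-c3cc(OC)c(OC)c(OC)c3)n2-c2ccc(N(C)C)cc2)cc1` gives 22000 nM, the lowest of the two true numbers in the set. Two steps lead to it: a 2.5-fold lower number from compound 1 to compound 3 (0.40 log units; beyond the scatter) and an at least 2.7-fold lower number from compound 2 to compound 3 (0.43 log units; beyond the scatter). Both replace the group on the saturated chain carbon bound to sulfur with (4-methoxyphenyl)carbonyl, and the second rests on a limit.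

Compound 4 `COc1ccc(C(=O)CSc2nnc(-c3cc(OC)c(OC)c(OC)c3)n2-c2ccc(N(C)C)cc2)cc1O` keeps all of compound 3 apart from one change, (hydroxy in place of hydrogen on an aromatic carbon). This is hydroxy in place of hydrogen on an aromatic carbon, ortho to a methoxy group, turning (4-methoxyphenyl)carbonyl into (3-hydroxy-4-methoxyphenyl)carbonyl. Among the compounds with values here, no measured compound carries a hydroxy group. Within the data shown here, the nearest precedent for a small substituent on an aromatic carbon is an at least 1.0-fold higher number from compound 1 to compound 2 (0.03 log units; that floor lies within the scatter), a floor that lies within the scatter, and it was measured without the carbonyl. The two larger steps concern a different change and set no size here. No shift beyond the scatter is therefore expected in this assay, though the uncertainty is wide. Expected step: a 1.1-fold lower number from compound 3 to compound 4 (0.04 log units; within the scatter). For compound 4 the estimate is 20000 nM, with an expected range of 8000 nM to 50000 nM.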

Compound 4, half-maximal inhibitory concentration: > 100000 nM
Compound 4 gave a limit, no number (the forecaster's own chance of this, stated with the estimate: 10%); middle value at least 5.0-fold (0.69 log units) from the limit.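

In this assay, hydroxy in place of hydrogen on an aromatic carbon ortho to a methoxy group proves not to be a silent change at this position: the step is an at least 4.5-fold higher number from compound 3 to compound 4 (0.65 log units; beyond the scatter). The advantage compound 3 held with (4-methoxyphenyl)carbonyl does not carry over to (3-hydroxy-4-methoxyphenyl)carbonyl, and the step against the phenyl of compound 1 is an at least 1.7-fold higher number from compound 1 to compound 4 (0.25 log units; that floor lies within the scatter), so compound 4 is not separated from compound 1 beyond the scatter. Compound 4 reads a limit of the assay and not a number, which makes these steps floors and leaves the step between compound 2 and compound 4 unreadable: the limit of > 100000 nM in this assay, at which 1 of the 4 values shown sits.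

The compounds shown leave open whether the loss belongs to hydroxy itself or to any substituent on this carbon, a question that an amine, a fluorine or a second methoxy at the same place would address. They also leave open how large the step from compound 3 to compound 4 truly is, as only its floor can be read.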